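Ring-nitrogen methylation in the bis-arylidene series

This account rests on a few compounds, and the source may have more. Where it says the series, first, only, none or still open, it means among the compounds named here.

Compound 1 `COc1ccccc1/C=c1/[nH]c(=O)/c(=C\c2cccc(Cl)c2Cl)[nH]c1=O` serves as the reference for the change considered here. In a functional assay on MCF7 cells (Homo sapiens) for cytotoxicity, read by CCK-8 assay, with a stated time of 72 h (a higher number here means a weaker inhibitor, a lower number a stronger inhibitor), compound 1 gives "not active" (no number reported), and no single number is available for it. Two further compounds of the series have numbers. Compound 2 `C=CCn1c(=O)/c(=C\c2cc(Br)ccc2F)[nH]c(=O)/c1=C\c1ccccc1OC` gives 28100 nM in this assay, and compound 3 `C=CCn1c(=O)/c(=C\c2cccc(Br)c2)[nH]c(=O)/c1=C\c1ccccc1OC` gives 5400 nM. Among the measured compounds shown here, the only step between measured compounds that differ in one place is a 5.2-fold lower number from compound 2 to compound 3 (0.72 log units; beyond the scatter), which concerns an aromatic halogen and not the ring nitrogen.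

Compound 4 `COc1ccccc1/C=c1\c(=O)[nH]/c(=C/c2cccc(Cl)c2Cl)c(=O)n1C` differs from compound 1 by methyl in place of hydrogen on an aromatic nitrogen. For the measured compounds named here, no measured pair isolates this change, so the step from compound 1 to compound 4 has no measured counterpart. Compounds 2 and 3 differ from compound 1 in more than one place and cannot be read as a step on this nitrogen, but both give numbers where compound 1 gives none, so a number for compound 4 in this assay is plausible though not assured. On this thin basis compound 4 is expected to give roughly 25000 nM in this assay, with a wide range from 5000 nM to 100000 nM, and a substantial chance that only "not active" is again reported.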

Compound 4, half-maximal inhibitory concentration: 200 nM
Compound 4: the middle estimate sits 130-fold (2.10 log units) above what was measured; the measured number lies below the stated range.
By their numbers in this assay, from the lowest: compound 4; then compound 3; then compound 2.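

In this assay compound 4 gives 200 nM and compound 1 gives "not active" (no number reported) and so no new step can be read between them. No measurement shown here bears on this result. The compounds shown leave open how much methyl in place of hydrogen on the aromatic nitrogen alone changes the number in this assay.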